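Swapping the Benzyl Substituent and Tolerance in Dog Kidney Cells

The compounds below may be only part of what the source reports. "The series", "measured", "known", "first", "only" and "open" are said of these compounds alone.

Compound 1, `Cc1ccc2cc(CN(Cc3ccc(Cl)cc3)Cc3ccc(C(C)C)cc3)c(=O)[nH]c2c1`: > 33000 nM
Compound 2, `Cc1ccc2[nH]c(=O)c(CN(Cc3ccc(OC(F)(F)F)cc3)Cc3ccc(C(C)(C)C)cc3)cc2c1`: > 5000 nM
Compound 3, `CCc1ccc2[nH]c(=O)c(CN(Cc3ccc(C(C)(C)C)cc3)[C@@H](C)c3ccc(OC)cc3)cc2c1`: > 5000 nM

All three compounds share one core and were tested in a toxicity assay on MDCK cells (Canis lupus familiaris) for cytotoxicity, read by crystal violet staining, with a stated time of 48 h; a lower number here means that less compound is tolerated, a higher number that more compound is tolerated. For compound 1 the result is a limit of the assay, not a number: > 33000 nM, the line at which (the limit of > 33000 nM in this assay, at which 1 of the 3 values shown sits). For compound 2 the result is also only a limit, > 5000 nM, the line at which (the limit of > 5000 nM in this assay, at which 2 of the 3 values shown sit). Compound 3 sits at the same kind of limit with > 5000 nM. No two measured compounds differ in only one place, so no single step is shown, and compound 2 stands at a limit like the others.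

Compound 4, `Cc1ccc2[nH]c(=O)c(CN(Cc3ccc(C(C)(C)C)cc3)Cc3ccc(N(C)C)c(Cl)c3)cc2c1`, has not yet been measured. It differs from compound 2 by 3-chloro-4-(dimethylamino)phenyl in place of 4-(trifluoromethoxy)phenyl on a saturated chain carbon bound to an amine nitrogen. Since compound 2 gives only a limit, the step that the limit leaves unreadable from compound 2 to compound 4 is expected to be none beyond the scatter, and another limit is likely. Compound 4 is expected to give about 8000 nM, within the range 3000 nM to 40000 nM.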

Compound 4, half-maximal cytotoxic concentration: > 10000 nM
Compound 4: no number, only a limit; the forecaster's own chance of this, stated with the estimate: 70%; middle value at least 1.2-fold (0.09 log units) from the limit.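

In this assay compound 4 gives > 10000 nM, a limit of the assay and not a number. Compound 2 also gives only a limit, so the step between these two compounds cannot be read. The compounds shown leave open whether swapping this benzyl substituent changes tolerance at all.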